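Trifluoromethyl for chloro at the alpha-2C adrenergic receptor

The source may hold more compounds than are shown below. What is called first, only, known or untested is meant among the compounds shown, and "the series" means these compounds.

Measured compounds:
compound 1 `CSc1ccc(C)cc1NCC1=NCCN1` — 81%
compound 2 `CSc1ccc(F)cc1NCC1=NCCN1` — 97%
compound 3 `CSc1ccc(Cl)cc1NCC1=NCCN1` — 92%

In a functional assay on CHO cells for agonist activity at Alpha-2C adrenergic receptor (Homo sapiens) (a higher number here means a larger maximal response, a lower number a smaller maximal response), compound 3 gives 92%, the second highest of the three numbers. It stands close to compound 2, separated by a number 5 percentage points lower from compound 2 to compound 3 (within the scatter), and clearly above compound 1, as a number 11 percentage points higher from compound 1 to compound 3 (beyond the scatter) shows. Compound 4 `CSc1ccc(C(F)(F)F)cc1NCC1=NCCN1` differs from compound 3 by trifluoromethyl in place of chloro on an aromatic carbon. Going by the values given here, no measured step covers this exchange; the nearest evidence is that swapping the substituent at this carbon moved the maximal response only modestly, as a number 16 percentage points higher from compound 1 to compound 2 (beyond the scatter) and a number 5 percentage points lower from compound 2 to compound 3 (within the scatter) show. A small change in this assay, if any beyond the scatter, is therefore expected for compound 4, namely a number 2 percentage points lower from compound 3 to compound 4 (within the scatter). Compound 4 is estimated at 90%, within 76% to 102%.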

Compound 4, largest response reached (reported as maximum), in percent of the reference or control that the assay uses: 45%
Estimate against measurement, compound 4: 45 percentage points above; the whole stated range lies above it.
By their numbers in this assay, from the lowest: compound 4; then compound 1; then compounds 3 and 2 (each within the scatter of the next).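

Trifluoromethyl on this aromatic carbon, para to the methylsulfanyl group, brings the first large fall in this assay, with a number 47 percentage points lower from compound 3 to compound 4 (beyond the scatter) and likewise a number 52 percentage points lower from compound 2 to compound 4 (beyond the scatter) and a number 36 percentage points lower from compound 1 to compound 4 (beyond the scatter) in the series. The position is therefore far less indifferent to its substituent than the modest steps among methyl, fluoro and chloro suggested. Nothing available explains the fall.

On these data alone, how a methoxy, a nitrile or an isopropyl group on this carbon would behave stays open. So does whether trifluoromethyl would cost as much with another group in place of the methylsulfanyl.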